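Alkyl versus aryl at the imidazole side chain

This account rests on a few compounds, and the source may have more. Where it says the series, first, only, none or still open, it means among the compounds named here.

Measured so far:
- compound 1 `CCCCc1cnc(CCc2ccc(-c3ccccc3C(=O)O)cc2)[nH]1`: 93 nM
- compound 2 `N#Cc1cccc(Cc2cnc(CCc3ccc(-c4ccccc4C(=O)O)cc3)[nH]2)c1`: 20 nM

In an in vitro functional assay on cells for agonist activity at Bombesin receptor subtype-3 (Mus musculus), read by luminescence and calcium flux (on this read-out higher numbers stand for an effect only at larger amounts of compound and lower numbers for an effect already at smaller amounts), compound 2 holds the lowest of the two numbers; its nearest neighbour is compound 1, and the step of a 4.7-fold lower number from compound 1 to compound 2 (0.67 log units; beyond the scatter) lies beyond the scatter. Compound 3 `CC(C)(C)CCc1cnc(CCc2ccc(-c3ccccc3C(=O)O)cc2)[nH]1` differs from compound 2 by neopentyl in place of 3-cyanophenyl on a saturated chain carbon bound to an aromatic carbon. For the measured compounds named here, the only measured step that bears on this change is a 4.7-fold lower number from compound 1 to compound 2 (0.67 log units; beyond the scatter), where an aryl group replaced an alkyl chain at the same place and the number fell. Compound 3 reverses that direction, returning to a saturated chain, so a rise in this assay of similar size is expected, landing near compound 1. The expected step is a 4.0-fold higher number from compound 2 to compound 3 (0.60 log units; beyond the scatter). Compound 3 is therefore estimated at 80 nM, with a range from 25 nM to 250 nM.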

Compound 3, half-maximal effective concentration: 6.2 nM
Beside the measured number, compound 3's estimate is 13-fold (1.11 log units) above it; measured number outside the range, below it.
By their numbers in this assay, from the lowest: compound 3; then compound 2; then compound 1.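

In this assay, an aromatic ring is not needed for a low number at this position: a 3.2-fold lower number from compound 2 to compound 3 (0.51 log units; beyond the scatter), with neopentyl in place of 3-cyanophenyl. Alkyl versus aryl therefore does not order these compounds, since the aryl compound 2 falls between two compounds with saturated chains; what separates those two is the chain end, with a 15-fold lower number from compound 1 to compound 3 (1.18 log units; beyond the scatter) for tert-butyl in place of ethyl on a saturated chain carbon, two bonds along the chain from an aromatic carbon. No measurement on hand accounts for either step.

The compounds shown leave open whether the tert-butyl end must be kept intact or whether an isopropyl or cyclohexyl end would serve as well. They also leave open whether a longer chain, or a chain ending in a hydroxyl or an amine, would hold the number of compound 3.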